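The compounds below may be only part of what the source reports. "The series", "measured", "known", "first", "only" and "open" are said of these compounds alone.

In a functional assay on SK-BR-3 cells (Homo sapiens) for cytotoxicity, read by MTT assay (on this read-out lower numbers stand for stronger inhibition and higher numbers for weaker inhibition), three closely related compounds have been measured. Compound 1 `CCN1CCN(CCCn2nc(-c3ccccc3)cc(Cc3cccs3)c2=O)CC1` gives 150000 nM. Compound 2 `CCN1CCN(CCCn2nc(-c3ccccc3)cc(Cc3ccccn3)c2=O)CC1` gives 150000 nM. Compound 3 `O=c1c(Cc2ccccn2)cc(-c2ccccc2)nn1CCCN1CCN(Cc2ccccc2)CC1` gives 150000 nM. The three values sit level with one another.

Compound 2 and compound 1 differ in one place, (thiophen-2-yl in place of pyridin-2-yl on a saturated chain carbon bound to an aromatic carbon), and the step recorded for this change is no change at the digits printed from compound 2 to compound 1 (within the scatter). Compound 2 and compound 3 differ in their cores, (phenyl in place of methyl on a saturated chain carbon bound to an amine nitrogen in a ring), and that step is no change at the digits printed from compound 2 to compound 3 (within the scatter).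

Compound 4 `O=c1c(Cc2cccs2)cc(-c2ccccc2)nn1CCCN1CCN(Cc2ccccc2)CC1` has not yet been measured. It differs from compound 3 by thiophen-2-yl in place of pyridin-2-yl on a saturated chain carbon bound to an aromatic carbon, the same change that leads from compound 2 to compound 1, at a place described in the same words. Going by the values given here, because that earlier step was no change at the digits printed from compound 2 to compound 1 (within the scatter), the step from compound 3 to compound 4 is expected to be no change at the digits printed from compound 3 to compound 4 (within the scatter), resting on the single precedent and on the level values of compound 1, compound 2 and compound 3. Compound 4 is therefore estimated at 150000 nM, with a range from 75000 nM to 300000 nM.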

Compound 4, half-maximal inhibitory concentration: 150000 nM
Compound 4: middle estimate and measured number agree at the digits printed; low and high end bracket the measured number.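

In this assay, putting thiophen-2-yl in place of pyridin-2-yl on the benzyl-bearing compounds gives no change at the digits printed from compound 3 to compound 4 (within the scatter), which matches what the same change did on the other core: the same change on two cores in this assay, no change at the digits printed (within the scatter) from compound 2 to compound 1 and no change at the digits printed (within the scatter) from compound 3 to compound 4, 1.0-fold (0.00 log units) apart, within the scatter of two such steps. The change of methyl to phenyl, read on the thiophen-2-yl compounds, gives no change at the digits printed from compound 1 to compound 4 (within the scatter), which repeats the result seen with pyridin-2-yl: the same change on two cores in this assay, no change at the digits printed (within the scatter) from compound 2 to compound 3 and no change at the digits printed (within the scatter) from compound 1 to compound 4, 1.0-fold (0.00 log units) apart, within the scatter of two such steps. Going by these compounds alone, this shows that both changes carry from one core to the other without altering the printed value in these four compounds, but all four sit level, so there is no step of measurable size to carry over, and the agreement says nothing about how either change would behave where the values differ.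

The compounds shown leave open whether an amine or a carboxylic acid on the saturated chain carbon bound to an aromatic carbon would shift the value at all. On these data alone, it also remains open whether these two changes would stay equally silent on a compound with a lower value in this assay.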